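Title: A fluorophenyl analogue after two halogenated limits

The source may hold more compounds than are shown below. What is called first, only, known or untested is meant among the compounds shown, and "the series" means these compounds.

Compounds measured so far:
- compound 1, `O=c1ccoc2cc(OCc3cn(Cc4ccc([N+](=O)[O-])cc4)nn3)ccc12`: 19300 nM
- compound 2, `O=c1ccoc2cc(OCc3cn(Cc4cccc(Br)c4)nn3)ccc12`: > 100000 nM
- compound 3, `O=c1ccoc2cc(OCc3cn(Cc4ccc(Cl)cc4Cl)nn3)ccc12`: > 100000 nM

Going by the values given here, in a functional assay on SW480 cells (Homo sapiens) for cytotoxicity, read by MTT assay, with a stated time of 48 h (on this read-out higher numbers stand for weaker inhibition and lower numbers for stronger inhibition), compound 1 gives 19300 nM, the only full number among the three. For compound 2 the assay reports only a limit, > 100000 nM. For compound 3 likewise only a limit is reported, > 100000 nM, so compound 3 stands at the weakest end that this assay can read; in fact (the limit of > 100000 nM in this assay, at which 2 of the 3 values shown sit).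

The step to the unmeasured compound 4, `O=c1ccoc2cc(OCc3cn(Cc4ccc(F)cc4)nn3)ccc12`, is 4-fluorophenyl in place of 2,4-dichlorophenyl on a saturated chain carbon bound to an aromatic nitrogen. Among the compounds with values here, no measured step covers this change directly. The steps that come closest are an at least 5.1-fold higher number from compound 1 to compound 3 (0.71 log units; beyond the scatter) and an at least 5.1-fold higher number from compound 1 to compound 2 (0.71 log units; beyond the scatter), both showing that swapping the 4-nitrophenyl group for a halogenated phenyl gave an at least modest weakening; the step that the two limits leave unreadable from compound 2 to compound 3 cannot be read. Since compound 4 carries yet another halogenated phenyl, no recovery beyond the scatter is expected, and the estimate for compound 4 is 90000 nM, between 30000 nM and 300000 nM, meaning an expected step of an at least 1.1-fold lower number from compound 3 to compound 4 (0.04 log units; that floor lies within the scatter).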

Compound 4, half-maximal inhibitory concentration: 11200 nM
For compound 4 the middle estimate is 8.0-fold (0.91 log units) above the measured one, and the stated range ends above it.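

In this assay, the 4-fluorophenyl group gives an at least 8.9-fold lower number from compound 3 to compound 4 (0.95 log units; beyond the scatter) and an at least 8.9-fold lower number from compound 2 to compound 4 (0.95 log units; beyond the scatter), so a halogen on the phenyl ring at this place does not by itself push a compound out of the readable range. Against the only earlier full number there is a 1.7-fold lower number from compound 1 to compound 4 (0.24 log units; within the scatter), so compound 1 and compound 4 cannot be told apart, and the 4-nitrophenyl group is not required for a readable value here. Compound 2 and compound 3 remain limits rather than numbers: the limit of > 100000 nM in this assay, at which 2 of the 4 values shown sit.

Compound 4 differs from compound 2 and compound 3 in both the halogen and its place on the ring, so the shown compounds do not separate these two changes. A 4-chlorophenyl group would address that question, while a 4-aminophenyl group would extend the comparison beyond halogens and nitro.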